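The source may hold more compounds than are shown below. What is called first, only, known or untested is meant among the compounds shown, and "the series" means these compounds.

Among the measured compounds shown here, compound 1, `CC(C)(O/N=C(\C(=O)N[C@@H]1C(=O)N(S(=O)(=O)O)[C@@H]1CN1CCCCC1=O)c1csc(N)n1)C(=O)O`, gives 214 h in a physicochemical assay for metabolic stability, read by HPLC and mass spectrometry, in phosphate buffer, at 37 degrees C, at pH 7.4 (on this read-out higher numbers stand for a longer-lived compound and lower numbers for a shorter-lived compound), the only plain number among the three measured compounds. Compound 2, `CC(C)(O/N=C(\C(=O)N[C@@H]1C(=O)N(S(=O)(=O)O)[C@@H]1CN1CCNC1=O)c1csc(N)n1)C(=O)O`, sits at a limit of this assay with > 1000 h. Compound 3, `CC(C)(O/N=C(\C(=O)N[C@@H]1C(=O)N(S(=O)(=O)O)[C@@H]1CN1C[C@@H](CN)OC1=O)c1csc(N)n1)C(=O)O`, likewise reaches a limit of this assay at > 37 h. Compound 4, `CC(C)(O/N=C(\C(=O)N[C@@H]1C(=O)N(S(=O)(=O)O)[C@@H]1Cn1ncnc1CN)c1csc(N)n1)C(=O)O`, differs from compound 1 by a group of 7 heavy atoms (3 carbon, 4 nitrogen; one five-membered aromatic ring with 3 hetero atoms) in place of a group of 7 heavy atoms (5 carbon, 1 nitrogen, 1 oxygen; one six-membered non-aromatic ring with 1 hetero atom), on a saturated chain carbon bound to a saturated ring carbon. For the measured compounds named here, only one step at the same place is readable, an at least 4.6-fold higher number from compound 1 to compound 2 (0.66 log units; beyond the scatter), and it points upward; the steps a step that the limit leaves unreadable from compound 1 to compound 3 and a step that the two limits leave unreadable from compound 2 to compound 3 give no size. Compound 4 is therefore expected to show a modest upward step of a 1.5-fold higher number from compound 1 to compound 4 (0.17 log units; within the scatter) in this assay. Compound 4 is estimated at 320 h, with a range from 100 h to 1000 h.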

Compound 4, half-life: > 37 h
Compound 4: a limit, no number (the forecaster's own chance of this, stated with the estimate: 20%); the middle value lies beyond the limit too.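

In this assay compound 4 gives > 37 h, which is a limit and not a number. Among the compounds shown here, no step from compound 1, compound 2 or compound 3 to compound 4 can be read. The compounds shown leave open how compound 4 ranks against these three.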